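One More Hydroxy on Compound 2

A few compounds are considered here, and "the series" means these few. Any claim that something is new, unique, unknown or untested is made for them only; others in the source may bear on it.

Of the compounds shown here, three have been measured in an ADME assay on MDCK cells (Canis lupus familiaris) for cytotoxicity; a lower number here means that less compound is tolerated, a higher number that more compound is tolerated. Compound 1 `O=[N+]([O-])C1=CNc2ncnn2C1O` gives 123000 nM. Compound 2 `CSc1nc2n(n1)C(c1ccc(O)cc1O)C([N+](=O)[O-])=NN2` gives 201000 nM. Compound 3 `O=[N+]([O-])C1=NNc2nc(C(F)(F)F)nn2C1c1ccc(O)c(O)c1` gives 183000 nM. Compound 2 lies within the scatter of both other compounds, so the three numbers cannot be told apart.

Compound 4 `CSc1nc2n(n1)C(c1c(O)cc(O)cc1O)C([N+](=O)[O-])=NN2` departs from compound 2 in one place: hydroxy in place of hydrogen on an aromatic carbon. This is hydroxy in place of hydrogen on an aromatic carbon. Among the compounds with values here, no measured pair differs in only one place, so the data offer no direct guide to this change. The measured compounds differ from one another in several places, yet compound 2 at 201000 nM and compound 1 at 123000 nM remain within the scatter of each other. On that basis, no change beyond the scatter is expected in this assay, and no clear direction can be given. The expected step of a 1.2-fold lower number from compound 2 to compound 4 (0.07 log units; within the scatter) should therefore be small. For compound 4 the estimated value is 170000 nM, with an expected range from 90000 nM to 320000 nM.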

Compound 4, half-maximal cytotoxic concentration: 877000 nM
Estimate against measurement, compound 4: 5.2-fold (0.71 log units) below, and the stated range ends below it.
By their numbers in this assay, from the lowest: compounds 1, 3 and 2 (each within the scatter of the next); then compound 4.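

Hydroxy in place of hydrogen on this aromatic carbon, ortho to a large group and meta to two hydroxy groups, gives the first single-place step that can be read in this assay: a 4.4-fold higher number from compound 2 to compound 4 (0.64 log units; beyond the scatter). The earlier compounds shown here differ from one another in several places and showed no separation beyond the scatter, whereas this one added hydroxy moves the number clearly upward, toward more compound being tolerated. Nothing available gives a reason for this step.

As far as these compounds go, whether the higher number belongs to hydroxy itself or would also follow from another group on this carbon, such as methoxy, fluorine or an amine, remains open. Also open, from the compounds shown here alone, is whether the step would hold on the aromatic ring of compound 3.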